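The source may report more compounds than this note shows. Statements on the series, on what has been measured and on what is new or still open speak of the compounds shown alone.

Series notes. Compound 1 `Cc1ncc2cnnc(O)n12`, compound 2 `CCCc1ncn2c(O)nncc12` and compound 3 `Cc1nc(C)n2c(O)nncc12` share one core; compound 4 `CCCc1nc(C)n2c(O)nncc12` is the member not yet measured. In a functional assay for inhibition, with Homo sapiens as the target (a higher number here means a weaker inhibitor, a lower number a stronger inhibitor), compound 1 gives > 48000 nM, which is a limit of the assay and not a number. In this assay compound 2 gives > 48000 nM, likewise a limit. In this assay compound 3 gives > 48000 nM, again a limit. The step that the two limits leave unreadable from compound 1 to compound 3 is unreadable because of the limit of > 48000 nM in this assay, at which 3 of the 3 values shown sit. Compound 3 therefore stands at the limit, as do the other two measured compounds. The change to compound 4 is ethyl in place of hydrogen on a saturated chain carbon bound to an aromatic carbon. Within the data shown here, no measured step bears on it, and all three values sit at the limit, so no readable step in this assay can be expected in either direction. Compound 2 carries the same propyl group and sits at a limit as well. The step expected here is a step that the limit leaves unreadable from compound 3 to compound 4, most likely again only a limit. Compound 4 is expected to give 60000 nM in this assay, within 20000 nM to 200000 nM.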

Compound 4, half-maximal inhibitory concentration: > 48000 nM
Compound 4: no number, only a limit; the forecaster's own chance of this, stated with the estimate: 85%; the middle value does not contradict the limit.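

In this assay, among these compounds, compound 4 gives > 48000 nM as a limit and not a number, so no step linking compound 1, compound 2, compound 3 and compound 4 can be read: the limit of > 48000 nM in this assay, at which 4 of the 4 values shown sit. The compounds shown leave open whether any substitution on the shared core gives a readable value in this assay at all.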